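Trimming a Side Chain on an Oxazolidinone Core

The compounds below may be only part of what the source reports. "The series", "measured", "known", "first", "only" and "open" are said of these compounds alone.

Measured so far in a physicochemical assay for lipophilicity, read by HPLC, measured as octanol-water partition; on this read-out higher numbers stand for higher lipophilicity and lower numbers for lower lipophilicity:
- compound 1 `O=C1O[C@@H](CO)CN1c1ccc(-n2cc(-c3ccccn3)cn2)c(F)c1` gives 1.67
- compound 2 `O=C1O[C@@H](CSc2cccs2)CN1c1ccc(-n2cc(-c3ccccn3)cn2)c(F)c1` gives 4.29
- compound 3 `CCC(=O)NC[C@H]1CN(c2ccc(-n3cc(-c4ccccn4)cn3)c(F)c2)C(=O)O1` gives 2.2

Compound 3 stands second highest of the three. Its nearest neighbour is compound 1, reached by the step of a number 0.53 log units higher from compound 1 to compound 3 (beyond the scatter); its furthest is compound 2, and the step of a number 2.09 log units lower from compound 2 to compound 3 (beyond the scatter) marks the distance.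

Compound 4 `CNC(=O)[C@H]1CN(c2ccc(-n3cc(-c4ccccn4)cn3)c(F)c2)C(=O)O1` differs from compound 3 in one place: methylcarbamoyl in place of (propanoylamino)methyl on a saturated ring carbon. The group that leaves has more heavy atoms than the group that enters, and both carry one hydrogen-bond donor and one hydrogen-bond acceptor. The measured steps all swap the group on the chain carbon of compound 1, so none matches this change exactly; they show only that a smaller, less carbon-rich group sits lower in this assay, as compound 1 does against compound 3.

Compound 4 is therefore expected near 1.4, with a likely range from 0.9 to 1.9. The expected step is a number 0.80 log units lower from compound 3 to compound 4 (beyond the scatter), downward and beyond the scatter.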

Compound 4, partition coefficient: 1.39
Beside the measured number, compound 4's estimate is 0.01 log units above it; the measured number falls inside the stated range.
By their numbers in this assay, from the lowest: compounds 4 and 1 (each within the scatter of the next); then compound 3; then compound 2.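

Swapping (propanoylamino)methyl for methylcarbamoyl on the saturated ring carbon leaves the hydrogen-bond donor and acceptor counts unchanged, yet in this assay the step is a number 0.81 log units lower from compound 3 to compound 4 (beyond the scatter), so a change in the group's size and carbon content can move this number without any change in those counts. Replacing ((thiophen-2-yl)sulfanyl)methyl gives the largest new step, a number 2.90 log units lower from compound 2 to compound 4 (beyond the scatter). Replacing hydroxymethyl gives a number 0.28 log units lower from compound 1 to compound 4 (within the scatter), so this assay does not separate methylcarbamoyl from hydroxymethyl at this position, even though the two groups differ in kind.

Nothing measured here explains why these numbers move as they do. Going by these compounds, it remains open where a longer amide such as ethylcarbamoyl, a carboxylic acid or an amine on the same ring carbon would fall.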